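The source may report more compounds than this note shows. Statements on the series, on what has been measured and on what is new or still open speak of the compounds shown alone.

In a functional assay on A549 cells (Homo sapiens) for antiproliferative activity (a lower number here means a stronger inhibitor of growth, a higher number a weaker inhibitor of growth), compound 1 (`CC/C=C\[C@H](C)[C@H](OC(N)=O)[C@@H](C)[C@H](O)[C@@H](C)C/C(C)=C\[C@H](C)[C@@H](O)[C@@H](C)/C=C\[C@@H](O)C[C@H](O)[C@H](C)CO`) gives 5000 nM and compound 2 (`CC/C=C\[C@H](C)[C@H](OC(N)=O)[C@@H](C)[C@H](O)[C@@H](C)C/C(C)=C\[C@H](C)[C@@H](O)[C@@H](C)/C=C\[C@@H](O)C[C@@H]1OC(=O)[C@H](C)C[C@H]1C`) gives 50 nM, so compound 2 holds the lower of the two numbers. Compound 3 (`CC/C=C\[C@H](C)[C@H](OC(N)=O)[C@@H](C)[C@H](O)[C@@H](C)C/C(C)=C\[C@H](C)[C@@H](O)[C@@H](C)/C=C\[C@@H](O)C[C@H]1CCC(=O)O1`) has not yet been measured. It differs from compound 2 at a single place, on a saturated chain carbon, two bonds along the chain from a double-bonded chain carbon and an oxygen on a saturated carbon: a group of 6 heavy atoms (4 carbon, 2 oxygen; one five-membered non-aromatic ring with 1 hetero atom) in place of a group of 9 heavy atoms (7 carbon, 2 oxygen; one six-membered non-aromatic ring with 1 hetero atom), on a saturated chain carbon, two bonds along the chain from a double-bonded chain carbon and an oxygen on a saturated carbon. Going by the values given here, one measured step bears on this place: a 100-fold lower number from compound 1 to compound 2 (2.00 log units; beyond the scatter). That step is large and beyond the scatter, and in it a group with one six-membered non-aromatic ring took the place of a group with no ring. Among the compounds with values here, compound 3 keeps a ring there, but a five-membered one in a smaller group, and no measured compound shows such a ring. Part of the distance seen in that step is therefore expected to be given back, without a full return to the open form. The expected move, towards a higher number, is a 10-fold higher number from compound 2 to compound 3 (1.00 log units; beyond the scatter). For compound 3 the estimated value is 500 nM, with an expected range from 120 nM to 2500 nM.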

Compound 3, concentration for 50% growth inhibition: 63 nM
Compound 3: the middle estimate sits 7.9-fold (0.90 log units) above what was measured; measured number below the stated range.
By their numbers in this assay, from the lowest: compounds 2 and 3 (each within the scatter of the next); then compound 1.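

In this assay, putting the five-membered ring group in place of the six-membered ring group, on a saturated chain carbon, gives a 1.3-fold higher number from compound 2 to compound 3 (0.10 log units; within the scatter), so this assay does not separate compound 2 from compound 3, although the group entering has 6 heavy atoms against 9 and 1 defined stereocentre against 3. The other new step, a 79-fold lower number from compound 1 to compound 3 (1.90 log units; beyond the scatter), is large and beyond the scatter, and there the two groups have the same count of 6 heavy atoms, so in these compounds the heavy-atom count of the group does not follow the numbers. The earlier step had changed ring presence and group size together, and these steps pull the two apart: among the three compounds, either ring goes with a much lower number than the open group, while the change of ring size leaves no readable difference.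

The data give no reason for the gap between the ring forms and the open form. Going by these compounds, it remains open whether a seven-membered ring, a ring with a nitrogen in place of the ring oxygen, or an open-chain ester at this place would stay level with compound 2 and compound 3 or fall back towards compound 1.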